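Removing the 4-bromophenyl group from compound 3

The source may hold more compounds than are shown below. What is called first, only, known or untested is meant among the compounds shown, and "the series" means these compounds.

Measured in a functional assay on HL-60 cells (Homo sapiens) for cytotoxicity, read by CCK-8 assay, with a stated time of 24 h; a higher number here means a weaker inhibitor, a lower number a stronger inhibitor:
- compound 1 `C=CC(=O)N1C(=O)CC(c2ccc(OC)cc2)Sc2ccccc21`: 92100 nM
- compound 2 `C=CC(=O)N1C(=O)CC(C)Sc2ccccc21`: 199000 nM
- compound 3 `C=CC(=O)N1C(=O)CC(c2ccc(Br)cc2)Sc2ccccc21`: 126000 nM

Compound 3 cannot be separated from either of the other two compounds, as a 1.4-fold higher number from compound 1 to compound 3 (0.14 log units; within the scatter) and a 1.6-fold lower number from compound 2 to compound 3 (0.20 log units; within the scatter) both stay within the scatter. The next structure, compound 4 `C=CC(=O)N1C(=O)CCSc2ccccc21`, carries hydrogen in place of 4-bromophenyl on a saturated ring carbon. Going by the values given here, no measured compound has hydrogen at this carbon. The nearest guide is a 2.2-fold higher number from compound 1 to compound 2 (0.33 log units; beyond the scatter), a modest step beyond the scatter on going from an aryl group to methyl. A similar modest rise in this assay is expected, though it may not clear the scatter. The estimated step is a 1.6-fold higher number from compound 3 to compound 4 (0.20 log units; within the scatter). For compound 4 the expected value is 200000 nM, with an estimated range of 100000 nM to 400000 nM.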

Compound 4, half-maximal inhibitory concentration: 44800 nM
For compound 4 the middle estimate is 4.5-fold (0.65 log units) above the measured one; measured number outside the range, below it.
By their numbers in this assay, from the lowest: compound 4; then compounds 1, 3 and 2 (each within the scatter of the next, the first and the last beyond it).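

In this assay the change to hydrogen on the saturated ring carbon next to the ring sulfur lowers the number from every group shown: a 2.8-fold lower number from compound 3 to compound 4 (0.45 log units; beyond the scatter) and a 4.4-fold lower number from compound 2 to compound 4 (0.65 log units; beyond the scatter) and a 2.1-fold lower number from compound 1 to compound 4 (0.31 log units; beyond the scatter) all lie beyond the scatter. Going by these compounds alone, compound 4 therefore stands lowest of the four, so the earlier compounds, all substituted at this carbon, could not show that hydrogen here outdoes methyl and both aryl groups. Nothing available explains this drop. On these data alone, whether a hydroxyl, an amine or a carboxylic acid at this carbon would keep the lower number remains open.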